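A few compounds are considered here, and "the series" means these few. Any claim that something is new, unique, unknown or untested is made for them only; others in the source may bear on it.

Compound 2 `O=C1Nc2ccc(S(=O)(=O)N3CCOCC3)cc2/C1=N/c1ccc(C(=O)O)cc1` gives in a functional assay on HepG2 cells (Homo sapiens) for cytotoxicity, read by sulforhodamine B assay, with a stated time of 24 h (on this read-out higher numbers stand for weaker inhibition and lower numbers for stronger inhibition), a value of 23100 nM. On the numbers shown it stands highest of the three, and so is the weakest inhibitor here, since the steps to both neighbours lie beyond the scatter. Compound 3 `O=C1Nc2ccc(S(=O)(=O)N3CCOCC3)cc2/C1=N/c1ccc(/N=C2\C(=O)Nc3ccc(S(=O)(=O)N4CCOCC4)cc32)cc1` gives 8840 nM, and compound 1 `N=c1oc2ccccc2cc1C(=O)N/N=C1\C(=O)Nc2ccc(S(=O)(=O)N3CCOCC3)cc21` gives 7820 nM. Compound 4 `O=C1Nc2ccc(S(=O)(=O)N3CCOCC3)cc2/C1=N/Nc1ccccc1` differs from compound 2 in one place: anilino in place of 4-carboxyphenyl on a double-bonded nitrogen. Among the measured compounds shown here, no measured pair shows this change, so only the spread of the three measured values guides an expectation. The step of a 2.3-fold lower number from compound 2 to compound 4 (0.36 log units; beyond the scatter) is expected to be small, in the direction of stronger inhibition, probably not far beyond the scatter. Compound 4 is therefore estimated at 10000 nM, with a range from 4000 nM to 25000 nM.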

Compound 4, half-maximal inhibitory concentration: 15600 nM
Estimate against measurement, compound 4: 1.6-fold (0.19 log units) below; measured number inside the range.
By their numbers in this assay, from the lowest: compounds 1, 3, 4 and 2 (each within the scatter of the next, the first and the last beyond it).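

In this assay, the only single-place comparison shown at this double-bonded nitrogen gives a 1.5-fold lower number from compound 2 to compound 4 (0.17 log units; within the scatter) for anilino in place of 4-carboxyphenyl. This position therefore tolerates the exchange of these two groups on the shared core without a change that can be told from scatter on this read-out. The measurements shown offer no explanation for this result. Left open is whether other groups on this nitrogen, such as a 4-aminophenyl, a 4-methoxyphenyl or a benzyl group, would separate from compound 2 beyond the scatter.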